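Pyrrolyl in place of cyclohexyl on a quinolone carboxamide

A few compounds are considered here, and "the series" means these few. Any claim that something is new, unique, unknown or untested is made for them only; others in the source may bear on it.

Compound 1 `COC(=O)c1cc(=O)c2cc(N)ccc2[nH]1` — > 33700 nM
Compound 2 `COc1cc(OC)c2c(=O)cc(C(=O)Nc3ccc(C4CCCCC4)cc3)[nH]c2c1` — "not determined" (no result reported)

In a functional assay on UoC-B1 cells (Homo sapiens) for antiproliferative activity, with a stated time of 72 h (on this read-out lower numbers stand for an effect already at smaller amounts and higher numbers for an effect only at larger amounts of compound), compound 1 gives only a limit, > 33700 nM. Compound 2 gives "not determined" (no result reported) in this assay, so it stands at no number here. For the measured compounds named here, the only value shown is a limit (the limit of > 33700 nM in this assay, at which 1 of the 2 values shown sits). Compound 3 `COc1cc(OC)c2c(=O)cc(C(=O)Nc3ccc(-n4cccc4)cc3)[nH]c2c1` differs from compound 2 in one place: 1H-pyrrol-1-yl in place of cyclohexyl on an aromatic carbon. Going by the values given here, with no measured step between compounds to draw on, the size and direction of the change in this assay cannot be taken from the data; a step of any size is possible. Compound 3 is expected to give 10000 nM in this assay, with a range from 1000 nM to 40000 nM.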

Compound 3, half-maximal effective concentration: 51800 nM
The estimate for compound 3 lay 5.2-fold (0.71 log units) below the measured number; the whole stated range lies below it.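

For the compounds shown here, no step to compound 3 can be read from compound 1 or compound 2 in this assay. The compounds shown leave open how far, and in which direction, 1H-pyrrol-1-yl in place of cyclohexyl shifts this read-out.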